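This account rests on a few compounds, and the source may have more. Where it says the series, first, only, none or still open, it means among the compounds named here.

Measured so far in a functional assay on MIA PaCa-2 cells (Homo sapiens) for inhibition, read by MTT assay, with a stated time of 72 h; a higher number here means a weaker inhibitor of growth, a lower number a stronger inhibitor of growth:
compound 1 `O=S(=O)(NCCCCNCc1ccc(Br)cc1)c1cc(C(F)(F)F)cc(C(F)(F)F)c1`; compound 1 gives 2100 nM
compound 2 `COc1ccc(CNCCCNS(=O)(=O)c2cc(C(F)(F)F)cc(C(F)(F)F)c2)cc1OC`; compound 2 gives 2800 nM

For the measured compounds named here, compound 2 carries the highest of the two numbers in this assay, but compound 1, its only neighbour, lies within the scatter of it, so the two cannot be ordered. Going by the values given here, no pair of measured compounds differs in a single place, hence no step size has yet been measured in this assay.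

Compound 3 `O=S(=O)(NCCCNCc1ccccc1)c1cc(C(F)(F)F)cc(C(F)(F)F)c1` differs from compound 2 by phenyl in place of 3,4-dimethoxyphenyl on a saturated chain carbon bound to an amine nitrogen. Nothing measured shows how this assay responds to that change. Among the compounds with values here, compound 1, which differs from compound 2 in more than one place, gives a number within the scatter of compound 2, so the series so far appears flat across changes at the aryl end. The step from compound 2 to compound 3 is therefore expected to be small, at most a slight rise, within or barely beyond the scatter a 1.1-fold higher number from compound 2 to compound 3 (0.06 log units; within the scatter). Compound 3 is estimated at 3200 nM in this assay, with a range from 1500 nM to 7000 nM.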

Compound 3, concentration for 50% growth inhibition: 11000 nM
Compound 3: middle estimate off by 3.4-fold (0.54 log units), on the low side, outside the stated range (above it).
By their numbers in this assay, from the lowest: compounds 1 and 2 (each within the scatter of the next); then compound 3.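

In this assay the aryl end of the series is not flat after all: with phenyl in place of 3,4-dimethoxyphenyl on a saturated chain carbon bound to an amine nitrogen, the data show a 3.9-fold higher number from compound 2 to compound 3 (0.59 log units; beyond the scatter), so growth inhibition weakens when the substituents are absent. The second comparison, a 5.2-fold higher number from compound 1 to compound 3 (0.72 log units; beyond the scatter), points the same way, but that change also alters the chain and cannot be credited to the bromine alone. No measurement on hand explains either rise.

On these data alone, whether both methoxy groups are needed, or a lone methoxy group would do, remains open. So does whether a chloro or methyl group on the phenyl would match the bromine on a chain of unchanged length.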